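Replacing the 4-hydroxyphenyl group of compound 3

The source may hold more compounds than are shown below. What is called first, only, known or untested is meant among the compounds shown, and "the series" means these compounds.

Measured in a functional assay on DU-145 cells (Homo sapiens) for inhibition, read by trypan blue exclusion, with a stated time of 96 h; a higher number here means a weaker inhibitor of growth, a lower number a stronger inhibitor of growth:
Compound 1 `O=C(/C(=C\c1c[nH]c2ccc(Cl)cc12)SCc1ccc(F)cc1)c1ccc(Br)cc1`: 1000 nM
Compound 2 `COc1ccc(/C=C(/SCc2ccc(F)cc2)C(=O)c2ccc(Br)cc2)cc1`: 50000 nM
Compound 3 `O=C(/C(=C\c1ccc(O)cc1)SCc1ccc(F)cc1)c1ccc(Br)cc1`: 10000 nM

Compound 3, at 10000 nM, stands in the middle of these three numbers, with only compound 1 lower. The next compound, compound 4 `Cc1cc(F)ccc1/C=C(/SCc1ccc(F)cc1)C(=O)c1ccc(Br)cc1`, differs from it in one group: 4-fluoro-2-methylphenyl in place of 4-hydroxyphenyl on a double-bonded chain carbon bound to a double-bonded chain carbon. Here 4-fluoro-2-methylphenyl takes the place of 4-hydroxyphenyl on a double-bonded chain carbon bound to a double-bonded chain carbon.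

All three measured steps involve that same place. Two of them start from the 5-chloro-1H-indol-3-yl group: a 50-fold higher number from compound 1 to compound 2 (1.70 log units; beyond the scatter), and a 10-fold higher number from compound 1 to compound 3 (1.00 log units; beyond the scatter). These are poor guides, since compound 4 keeps a phenyl ring there. The closest guide is the step between two phenyl compounds, a 5.0-fold lower number from compound 2 to compound 3 (0.70 log units; beyond the scatter). Compound 3 has the lower number in that step, which gives a weak hint that compound 4 may lie slightly higher. Going by the values given here, no measured compound shows the effect of the new group itself, so the direction remains uncertain.

In this assay the expected step is small: a 1.5-fold higher number from compound 3 to compound 4 (0.18 log units; within the scatter). For compound 4 the estimated value is 15000 nM, with an expected range of 3000 nM to 60000 nM.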

Compound 4, concentration for 50% growth inhibition: 10000 nM
Estimate against measurement, compound 4: 1.5-fold (0.18 log units) above; low and high end bracket the measured number.
By their numbers in this assay, from the lowest: compound 1; then compounds 3 and 4 (each within the scatter of the next); then compound 2.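

In this assay, the step (no change at the digits printed from compound 3 to compound 4 (within the scatter)) shows that the hydroxyl hydrogen of 4-hydroxyphenyl is not needed at this place to reach this number, since 4-fluoro-2-methylphenyl has no hydrogen-bond donor. The step (a 5.0-fold lower number from compound 2 to compound 4 (0.70 log units; beyond the scatter)) points the same way: compound 2 and compound 4 both lack that hydrogen yet differ beyond the scatter, so the earlier gap between compound 2 and compound 3 cannot be read as a simple need for it. The 5-chloro-1H-indol-3-yl group of compound 1 keeps the lowest number in the set, as the step (a 10-fold higher number from compound 1 to compound 4 (1.00 log units; beyond the scatter)) shows, but nothing on hand explains any of these steps.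

From the compounds shown here alone, whether the fluorine or the methyl group of 4-fluoro-2-methylphenyl matters on its own stays open, as does whether a phenyl ring carrying only one of them would give the same number as compound 4. Also open, going by these compounds, is how a phenyl ring bearing an amine or a carboxylic acid would read here, and whether an indol-3-yl group without its chlorine would hold the lower number of compound 1.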